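The source may report more compounds than this note shows. Statements on the series, on what has been measured and on what is new or still open speak of the compounds shown alone.

Compound 1 `c1cncc(-c2cc3c(-c4cccc(N5CCNCC5)n4)n[nH]c3cn2)c1` was tested in an ADME assay on microsomes from intestine (Rattus norvegicus) for metabolic stability, using NADPH, with a stated time of 60 min, in the presence of a further agent that is not named here (a higher number here means that more of the compound is left, a lower number that less of the compound is left), and compound 1 was reported as "unstable" (no number reported), without a number, so it stands only as a compound of which little is left. A second compound, compound 2 `Cc1cncc(-c2cc3c(cnn3-c3cccc(N4CCCNCC4)n3)nn2)n1`, has a different core but carries a 1,4-diazepan-1-yl group, and in this assay compound 2 gives 80%. Compound 3 `c1cncc(-c2cc3c(-c4cccc(N5CCCNCC5)n4)n[nH]c3cn2)c1` keeps the core of compound 1 and differs from it in one place: 1,4-diazepan-1-yl in place of piperazin-1-yl on an aromatic carbon. For the measured compounds named here, there is no measured step of this kind to lean on, and compound 1 has no number, so the size of the step in this assay cannot be read off; a rise is expected, but a wide one is plausible, and a result that again stays within the scatter of a low value is possible. Compound 3 is expected to give 30% in this assay, between 5% and 70%.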

Compound 3, percent of the compound remaining: "unstable" (no number reported)
The entry for compound 3 holds no number, so the estimate cannot be set against anything.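

For the compounds shown here, compound 1 and compound 3 are both reported only as unstable in this assay, without a number, so no step between them can be read. No measured evidence bears on this result. The compounds shown leave open how much of each remains, and whether 1,4-diazepan-1-yl in place of piperazin-1-yl changes that amount.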